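Arylthio variation on the diamino core: compound 4 outlook

The source may report more compounds than this note shows. Statements on the series, on what has been measured and on what is new or still open speak of the compounds shown alone.

Measured so far, in a functional assay on SF-295 cells (Homo sapiens) for inhibition, read by sulforhodamine B assay, with a stated time of 48 h; a higher number here means a weaker inhibitor of growth, a lower number a stronger inhibitor of growth:
compound 1, `Nc1cc(N)c2nc(-c3ccccc3)c(Sc3ccc(F)cc3)nc2c1`, 30200 nM
compound 2, `Nc1cc(N)c2nc(-c3ccccc3)c(Sc3ccc(Cl)c(Cl)c3)nc2c1`, 60300 nM
compound 3, `COc1ccc(CNc2nc3cc(N)cc(N)c3nc2-c2ccccc2)cc1`, 32400 nM

Compound 2 carries the highest number of the three, but its separation from compound 3 and from compound 1 is in both cases within the scatter, so no order among the three can be read from these values.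

The step to compound 4, `COc1ccc(Sc2nc3cc(N)cc(N)c3nc2-c2ccccc2)cc1`, is 4-methoxyphenyl in place of 3,4-dichlorophenyl on a sulfur. Among the compounds with values here, the one measured step that bears on it is the change of the group on the sulfur, a 2.0-fold higher number from compound 1 to compound 2 (0.30 log units; within the scatter), which was within the scatter. Compound 3, which carries a 4-methoxyphenyl on a different linker, gives 32400 nM, a number close to that of compound 2 and within the scatter of it. Nothing among these compounds points to a change beyond the scatter from exchanging the group on the sulfur.

For compound 4 the expected step is therefore a 1.6-fold lower number from compound 2 to compound 4 (0.20 log units; within the scatter), no more than the scatter. In this assay compound 4 is estimated at 38000 nM, with a range from 15000 nM to 95000 nM.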

Compound 4, concentration for total growth inhibition: < 100000 nM
Compound 4: only a limit was reported; the forecaster's own chance of this, stated with the estimate: 10%; the middle value is on the limit's open side.
By their numbers in this assay, from the lowest: compounds 1, 3 and 2 (each within the scatter of the next).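

In this assay compound 4 gives < 100000 nM, which is a limit and not a number. No step from compound 1 or compound 2 to compound 4 can be read: the limit of < 100000 nM in this assay, at which 1 of the 4 values shown sits.

The compounds shown leave open how 4-methoxyphenyl on a sulfur compares with 3,4-dichlorophenyl there.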